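This account rests on a few compounds, and the source may have more. Where it says the series, first, only, none or still open, it means among the compounds named here.

Compound 3, `CN(C(=O)N1CC[C@H](n2cnc3cc(-c4ccc(Cl)cc4)sc3c2=O)C1)[C@H]1CCN(CC2CCCCC2)C1`, gives 53 nM in a functional assay for antagonist activity at melanin-concentrating hormone receptor 1 (Homo sapiens), read by GTPgammaS binding (on this read-out lower numbers stand for stronger inhibition and higher numbers for weaker inhibition), the highest number among the three measured compounds. Compound 1, `CN(C(=O)N1CC[C@H](n2cnc3cc(-c4ccc(Cl)cc4)sc3c2=O)C1)[C@H]1CCN(C2CCC(C)(C)CC2)C1`, gives 10 nM, and compound 2, `CN(C(=O)N1CC[C@H](n2cnc3cc(-c4ccc(Cl)cc4)sc3c2=O)C1)[C@H]1CCN(CC2CC2)C1`, gives 10 nM. The steps leading to compound 3 were a 5.3-fold higher number from compound 1 to compound 3 (0.72 log units; beyond the scatter) and a 5.3-fold higher number from compound 2 to compound 3 (0.72 log units; beyond the scatter), whereas between the other two compounds no change at the digits printed from compound 1 to compound 2 (within the scatter). Compound 4, `CN(C(=O)N1CC[C@H](n2cnc3cc(-c4ccc(Cl)cc4)sc3c2=O)C1)[C@H]1CCN(CC2CCOC2)C1`, differs from compound 3 by oxolan-3-yl in place of cyclohexyl on a saturated chain carbon bound to an amine nitrogen in a ring. Going by the values given here, the step that bears most on this change is the one from compound 2 to compound 3, where cyclohexyl in place of cyclopropyl on the same saturated chain carbon raised the number by a modest margin. Among the compounds with values here, compound 4 moves away from cyclohexyl towards a five-membered non-aromatic ring with one hetero atom, so it is expected to recover part of that loss, although only a single relevant step is available and the expectation is therefore loose. Compound 4 is expected to show a step of a 2.7-fold lower number from compound 3 to compound 4 (0.42 log units; beyond the scatter) in this assay. The estimate for compound 4 is 20 nM, with a range from 7 nM to 60 nM.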

Compound 4, half-maximal inhibitory concentration: 10 nM
For compound 4 the middle estimate is 2.0-fold (0.30 log units) above the measured one; measured number inside the range.
By their numbers in this assay, from the lowest: compounds 1, 2 and 4 (each within the scatter of the next); then compound 3.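

At the saturated chain carbon bound to an amine nitrogen in a ring, the higher number seen with cyclohexyl does not carry over to every ring: in this assay oxolan-3-yl gives a 5.3-fold lower number from compound 3 to compound 4 (0.72 log units; beyond the scatter). The oxolan-3-yl group also matches cyclopropyl, with no change at the digits printed from compound 2 to compound 4 (within the scatter), and (oxolan-3-yl)methyl matches 4,4-dimethylcyclohexyl on the amine nitrogen, with no change at the digits printed from compound 1 to compound 4 (within the scatter). Of the three rings on this carbon, only cyclohexyl now stands apart, and a ring with one hydrogen-bond acceptor is accepted here as well as cyclopropyl, though no measurement offered explains this difference.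

The compounds shown leave open whether the ring oxygen or the smaller ring size accounts for the difference from cyclohexyl. A cyclopentyl group and an oxan-4-yl group on the same carbon would separate these two.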